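Dichloro Aryl Swap in a Cytotoxic Curcuminoid Series

This account rests on a few compounds, and the source may have more. Where it says the series, first, only, none or still open, it means among the compounds named here.

Measured compounds:
compound 1 `COc1ccc(/C=C2\CCC/C(=C\c3ccc(Cl)cc3)C2=O)cc1OC`: 10100 nM
compound 2 `COc1ccc(/C=C2\CCC/C(=C\c3ccc(Br)cc3)C2=O)cc1OC`: 16000 nM

In a functional assay on A549 cells (Homo sapiens) for cytotoxicity, read by MTT assay, with a stated time of 72 h (on this read-out higher numbers stand for weaker inhibition and lower numbers for stronger inhibition), compound 2 gives 16000 nM, the higher of the two numbers; its nearest neighbour is compound 1 at 10100 nM, and the step of a 1.6-fold higher number from compound 1 to compound 2 (0.20 log units; within the scatter) is a halogen exchange. Compound 3 `COc1ccc(/C=C2\CCC/C(=C\c3cccc(Cl)c3Cl)C2=O)cc1OC` is not yet measured. It differs from compound 2 by 2,3-dichlorophenyl in place of 4-bromophenyl on a double-bonded chain carbon bound to a double-bonded ring carbon. For the measured compounds named here, no measured step covers this change; only the small halogen step is available. Compound 3 is therefore expected to show a step of a 1.3-fold lower number from compound 2 to compound 3 (0.12 log units; within the scatter) that stays near the scatter, with an estimated 12000 nM and a range from 4000 nM to 40000 nM.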

Compound 3, half-maximal inhibitory concentration: > 20000 nM
Compound 3 ended at the assay's limit (the forecaster's own chance of this, stated with the estimate: 10%); middle value at least 1.6-fold (0.22 log units) from the limit.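

Compound 3 alone among the three reaches a limit in this assay rather than giving a number: the limit of > 20000 nM in this assay, at which 1 of the 3 values shown sits.

Putting 2,3-dichlorophenyl on this double-bonded chain carbon gives an at least 1.2-fold higher number from compound 2 to compound 3 (0.09 log units; that floor lies within the scatter) and an at least 1.9-fold higher number from compound 1 to compound 3 (0.29 log units; that floor lies within the scatter). Both steps are floors within the scatter, so the change may be small or large, though nothing points to stronger inhibition.

As far as these compounds go, the real number for compound 3 remains unknown. Also open, from the compounds shown here alone, is whether an amine or a carboxylic acid on the phenyl ring at this place would give a lower number.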